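A Shorter Alkoxy Arm Replaces the Dichlorophenyl Ketone

The compounds below may be only part of what the source reports. "The series", "measured", "known", "first", "only" and "open" are said of these compounds alone.

Three chalcone-type compounds sharing one core have been tested in a functional assay on A549 cells (Homo sapiens) for antiproliferative activity, read by MTT assay, with a stated time of 48 h; on this read-out higher numbers stand for weaker inhibition and lower numbers for stronger inhibition. Compound 2 `COc1ccc(/C=C/c2cc(OC)cc(OC)c2/C=C/C(=O)c2ccc(Cl)c(Cl)c2)cc1` gives 5.9 ug/mL, the lowest of the three numbers shown, yet neither neighbour sits outside the usual scatter of it. Compound 1 `CCCCCCCCCCCCOc1ccc(C(=O)/C=C/c2c(/C=C/c3ccc(OC)cc3)cc(OC)cc2OC)cc1` gives 7.9 ug/mL, and compound 3 `COc1ccc(/C=C/c2cc(OC)cc(OC)c2/C=C/C(=O)c2cccc(Br)c2)cc1` gives 8.1 ug/mL. Among the measured compounds shown here, the only single-point step among the measured compounds, a 1.4-fold higher number from compound 2 to compound 3 (0.14 log units; within the scatter), falls within the scatter.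

Compound 4 `CCOc1ccc(C(=O)/C=C/c2c(/C=C/c3ccc(OC)cc3)cc(OC)cc2OC)cc1` is not yet measured. Its difference from compound 2 is 4-ethoxyphenyl in place of 3,4-dichlorophenyl on a carbonyl carbon. For the measured compounds named here, no measured step covers this exact change; the closest guidance is that compound 1, which also carries an alkoxyphenyl on the carbonyl carbon, gives 7.9 ug/mL, a number not separated from that of compound 2 beyond the scatter. Because compound 1 shows 7.9 ug/mL and compound 2 shows 5.9 ug/mL, compound 4 is expected to land close to both. The estimated step of a 1.2-fold higher number from compound 2 to compound 4 (0.07 log units; within the scatter) is expected to stay within the scatter. Compound 4 is estimated at 7 ug/mL, in the range 3.5 ug/mL to 14 ug/mL.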

Compound 4, half-maximal inhibitory concentration: 7.5 ug/mL
Compound 4: middle estimate off by 1.1-fold (0.03 log units), on the low side; the measured number falls inside the stated range.
By their numbers in this assay, from the lowest: compounds 2, 4, 1 and 3 (each within the scatter of the next).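

In this assay, among the compounds shown here, the new 4-ethoxyphenyl group on the carbonyl carbon is set against both halogen-bearing rings for the first time: 3,4-dichlorophenyl gives way to it with a 1.3-fold higher number from compound 2 to compound 4 (0.10 log units; within the scatter) and 3-bromophenyl gives way to it with a 1.1-fold lower number from compound 3 to compound 4 (0.03 log units; within the scatter) and neither step separates the groups. Within the alkoxy arm, hydrogen in place of decyl on the saturated chain carbon gives a 1.1-fold lower number from compound 1 to compound 4 (0.02 log units; within the scatter) so the long chain of compound 1 and the ethoxy group of compound 4 cannot be told apart here. All four compounds thus stay within the scatter of one another, and no group at this position has yet moved the number clearly.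

Going by these compounds, whether an amine or a carboxylic acid in place of the ethoxy group would do so remains open. Nothing shown gives a reason for these numbers.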